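The source may report more compounds than this note shows. Statements on the series, on what has been measured and on what is new or still open speak of the compounds shown alone.

Values in a functional assay on the whole organism for antagonist activity, with Mus musculus as the target; on this read-out lower numbers stand for an effect already at smaller amounts and higher numbers for an effect only at larger amounts of compound:
Compound 1 `CSc1nc(-c2ccccc2)n(C)n1`: > 100 mg/kg (a limit)
Compound 2 `Cn1nc([S+](C)[O-])nc1-c1ccccc1`: > 200 mg/kg (a limit)

In this assay compound 2 stands only at a limit, > 200 mg/kg, and no actual number is known for it. Among the measured compounds shown here, the one measured step that bears on what comes next is a step that the two limits leave unreadable from compound 1 to compound 2, so it offers no size to carry forward. Compound 3 `Cn1nc(S(C)(=O)=O)nc1-c1ccccc1` differs from compound 2 at a single place: a group of 4 heavy atoms (1 carbon, 2 oxygen, 1 sulfur; no ring) in place of a group of 3 heavy atoms (1 carbon, 1 oxygen, 1 sulfur; no ring), on an aromatic carbon. Methylsulfonyl enters on the aromatic carbon between two ring nitrogen atoms. With only limits to go on, no step beyond the usual scatter is expected in either direction. The expected step is a number no higher from compound 2 to compound 3 (the limit leaves the size open). Compound 3 is estimated at 200 mg/kg, with an expected range of 100 mg/kg to 400 mg/kg. A further limit, rather than a number, is the likeliest report from this assay.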

Compound 3, dose for half-maximal effect: > 200 mg/kg
Compound 3: only a limit was reported; the forecaster's own chance of this, stated with the estimate: 85%; the middle value sits exactly at the limit.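

Among the compounds shown here, compound 1, compound 2 and compound 3 all stand only as limits in this assay, and no step between them can be read. The compounds shown leave open the dose for half-maximal effect of each, and whether exchanging these sulfur-bearing groups changes it at all.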